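Replacing the 3,5-dichlorophenoxy group of compound 2

The source may report more compounds than this note shows. Statements on the series, on what has been measured and on what is new or still open speak of the compounds shown alone.

Measured in a functional assay on MDA-MB-231 cells (Homo sapiens) for antiproliferative activity, read by MTT assay, with a stated time of 24 h; a lower number here means a stronger inhibitor, a higher number a weaker inhibitor:
- compound 1 `Cc1ccc(NC(=O)N2CCN(c3nccc(Oc4cc(Cl)cc(Cl)c4)n3)CC2)cc1`: 11600 nM
- compound 2 `O=C(Nc1ccc(C(F)(F)F)cc1)N1CCN(c2nccc(Oc3cc(Cl)cc(Cl)c3)n2)CC1`: 1540 nM
- compound 3 `CN1CCN(CC(=O)N2CCN(c3nccc(Oc4cc(Cl)cc(Cl)c4)n3)CC2)CC1`: 24700 nM

Of these three, compound 2 has the lowest number, and its gaps to the other two lie beyond the scatter. Trifluoromethyl in place of methyl on an aromatic carbon gave a 7.5-fold lower number from compound 1 to compound 2 (0.88 log units; beyond the scatter), a modest step. The change from (4-(trifluoromethyl)phenyl)amino to (4-methylpiperazin-1-yl)methyl on a carbonyl carbon gave a 16-fold higher number from compound 2 to compound 3 (1.21 log units; beyond the scatter), a large one. The third measured step, a 2.1-fold higher number from compound 1 to compound 3 (0.33 log units; beyond the scatter), is also modest.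

Compound 4 `COc1cccc(Nc2ccnc(N3CCN(C(=O)Nc4ccc(C(F)(F)F)cc4)CC3)n2)c1` keeps the (4-(trifluoromethyl)phenyl)amino group of compound 2 and changes a different part of the molecule: (3-methoxyphenyl)amino in place of 3,5-dichlorophenoxy on an aromatic carbon. Here, (3-methoxyphenyl)amino stands in place of 3,5-dichlorophenoxy. Going by the values given here, no measured step touches this place, so the three steps show only how far single changes have moved the number in this small set. The direction remains uncertain, but compound 2 already holds the lowest value at 1540 nM, so a rise seems likelier than a further fall. The estimated change in this assay is a 2.3-fold higher number from compound 2 to compound 4 (0.36 log units; beyond the scatter), a modest expected step toward a higher number. For compound 4 the estimated value is 3500 nM, with an expected range from 900 nM to 14000 nM.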

Compound 4, half-maximal inhibitory concentration: 1240 nM
Compound 4: middle estimate off by 2.8-fold (0.45 log units), on the high side; the range from low to high includes it.
By their numbers in this assay, from the lowest: compounds 4 and 2 (each within the scatter of the next); then compound 1; then compound 3.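

In this assay, putting (3-methoxyphenyl)amino in place of 3,5-dichlorophenoxy gives a 1.2-fold lower number from compound 2 to compound 4 (0.09 log units; within the scatter), so the two compounds cannot be told apart. Going by these compounds alone, compounds 1, 2 and 3 all carry 3,5-dichlorophenoxy and vary only at the other end of the molecule, so this is the first view of this position: with the (4-(trifluoromethyl)phenyl)amino group in place, it accepts a group with no chlorine, with nitrogen rather than oxygen joining the ring to the core, and with one hydrogen-bond donor where there was none, and the number stays within the scatter. Nothing measured here gives a reason for this match.

This single swap changes the linking atom and the groups on the outer ring together, so a direct comparison with (3,5-dichlorophenyl)amino or 3-methoxyphenoxy would be needed to tell the two changes apart. On these data alone, it also remains open whether (3-methoxyphenyl)amino would behave the same way alongside the (4-methylphenyl)amino group of compound 1 or the (4-methylpiperazin-1-yl)methyl group of compound 3.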